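The source may report more compounds than this note shows. Statements on the series, on what has been measured and on what is new or still open speak of the compounds shown alone.

Working notes on the series.

Compound 1 `CSc1nc(-c2ccco2)c(C#N)c(=O)n1C` and compound 2 `CSc1nc(-c2cccs2)c(C#N)c(=O)n1C` share one core; compound 3 `CCOC(=O)c1cnn(-c2nc(-c3ccco3)c(C#N)c(=O)n2C)c1N` and compound 4 `CCOC(=O)c1cnn(-c2nc(-c3cccs3)c(C#N)c(=O)n2C)c1N` share another. How the two cores differ is not broken down here. In a functional assay, with a stated time of 10 min (a lower number here means a stronger inhibitor, a higher number a weaker inhibitor), compound 1 gives 79 ug/mL, and compound 2 gives 72 ug/mL. Compound 3 gives 104 ug/mL in this assay; its value and those of compound 1 and compound 2 lie within the scatter of one another.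

The change from compound 1 to compound 2 is thiophen-2-yl in place of furan-2-yl on an aromatic carbon, and it made a 1.1-fold lower number from compound 1 to compound 2 (0.04 log units; within the scatter). The change from compound 3 to compound 4 is thiophen-2-yl in place of furan-2-yl on an aromatic carbon. It is the same kind of change, not the same: in compound 1 the place is meta to a methylsulfanyl group, in compound 3 it is meta to a large group.

For compound 4 a step of about the size of the earlier one is expected, a 1.1-fold lower number from compound 3 to compound 4 (0.04 log units; within the scatter), resting on the step from compound 1 to compound 2 in this assay. The estimate for compound 4 in this assay is 95 ug/mL, expected between 55 ug/mL and 165 ug/mL.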

Compound 4, half-maximal inhibitory concentration: 109 ug/mL
Beside the measured number, compound 4's estimate is 1.1-fold (0.06 log units) below it; the range from low to high includes it.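

In this assay, thiophen-2-yl in place of furan-2-yl on the core of compound 3 gives a 1.0-fold higher number from compound 3 to compound 4 (0.02 log units; within the scatter). Set beside the earlier step, the change shows no difference between the two cores that can be read: the same change on two cores in this assay, a 1.1-fold lower number (0.04 log units; within the scatter) from compound 1 to compound 2 and a 1.0-fold higher number (0.02 log units; within the scatter) from compound 3 to compound 4, 1.1-fold (0.06 log units) apart, within the scatter of two such steps This shows that, on these two cores, the step stays within the scatter whether the group meta to the site is methylsulfanyl or the large group, but it does not show that the two rings can be exchanged on any other core, and two steps this small say little about whether a step of real size would carry across in the same way.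

The compounds shown leave open whether a different group at this place, such as a phenyl ring or an amine, would give a step beyond the scatter. Also open, going by these compounds, is whether the same exchange would behave alike on a core carrying a carboxylic acid in place of the ethyl ester.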